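The compounds below may be only part of what the source reports. "The series", "measured", "known", "first", "only" and "open" are said of these compounds alone.

Measured in a functional assay on MCF7 cells (Homo sapiens) for cytotoxicity; a higher number here means a weaker inhibitor, a lower number a stronger inhibitor:
compound 1, `COc1ccc(Cn2cc(/C=N\NC(=O)c3c[nH]c4ccccc34)c3ccccc32)cc1`, 12400 nM
compound 2, `COc1ccc(Cn2cc(/C=N\NC(=O)c3c[nH]c4ccccc34)c3cc(OC)ccc32)cc1`, 15000 nM

Within the data shown here, compound 2 sits at the higher of the two numbers in this assay, yet the single step between them, a 1.2-fold higher number from compound 1 to compound 2 (0.08 log units; within the scatter), falls within the scatter, so no order is claimed. Compound 3, `COc1ccc(Cn2cc(/C=N\NC(=O)c3c[nH]c4ccc(Br)cc34)c3cc(OC)ccc32)cc1`, differs from compound 2 by bromo in place of hydrogen on an aromatic carbon. Among the measured compounds shown here, no measured step touches a bromo substitution; the only step recorded concerns methoxy and stayed within the scatter. For compound 3 the expected step is therefore a 1.2-fold lower number from compound 2 to compound 3 (0.06 log units; within the scatter), with no change beyond the scatter foreseen. The estimate for compound 3 is 13000 nM, within 5000 nM to 40000 nM.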

Compound 3, half-maximal inhibitory concentration: 3100 nM
Compound 3: middle estimate off by 4.2-fold (0.62 log units), on the high side, and the stated range ends above it.
By their numbers in this assay, from the lowest: compound 3; then compounds 1 and 2 (each within the scatter of the next).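

In this assay, among these compounds, the change from 1H-indol-3-yl to 5-bromo-1H-indol-3-yl gives a 4.8-fold lower number from compound 2 to compound 3 (0.68 log units; beyond the scatter) and is the only step so far beyond the scatter. The methoxy step, a 1.2-fold higher number from compound 1 to compound 2 (0.08 log units; within the scatter), stayed within it, so this bromo position is the first place in the series shown to respond. No measured evidence bears on the reason for this step.

Open, from the compounds shown here alone, is whether chloro, methyl or an amine at this same place would give a step of similar size. Also open, going by these compounds, is whether bromo gives the same step on the core of compound 1.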